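The source may hold more compounds than are shown below. What is called first, only, known or untested is meant among the compounds shown, and "the series" means these compounds.

Of the compounds shown here, two sharing one core have been tested so far: compound 1 (`N#C/C(=C\c1ccccc1OS(=O)(=O)c1ccc(Cl)cc1)C(=O)Nc1nnc(Cc2ccc(F)cc2)s1`) and compound 2 (`Cc1ccc(Cc2nnc(NC(=O)/C(C#N)=C/c3ccccc3OS(=O)(=O)c3ccc(C)cc3)s2)cc1`). In a functional assay on HL-60 cells (Homo sapiens) for inhibition, read by CCK-8 assay, with a stated time of 48 h, tested at 20 uM (a higher number here means more inhibition of growth at the concentration tested, a lower number less inhibition of growth), compound 1 gives 20% and compound 2 gives 17% as its result. Compound 2 therefore stands within the usual scatter of compound 1, and the two cannot be ranked against each other.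

Compound 3 (`Cc1ccc(Cc2nnc(NC(=O)/C(C#N)=C/c3ccccc3OS(=O)(=O)c3ccc(Cl)cc3)s2)cc1`) differs from compound 2 in one place, with chloro in place of methyl on an aromatic carbon, para to a large group. This turns (4-methylphenyl)sulfonyl into (4-chlorophenyl)sulfonyl (chloro in place of methyl on an aromatic carbon). Within the data shown here, no pair of tested compounds shows this exchange on its own, so the data contain no direct measure of its size.

The expectation starts from compound 2 at 17% and takes into account that compound 1 at 20% lies within the scatter of it. In this assay the estimated step of a number 3 percentage points higher from compound 2 to compound 3 (within the scatter) is expected to stay inside the scatter, with no clear direction. For compound 3 the estimate is 20% with 8% to 35% as the expected range.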

Compound 3, percent growth inhibition at one concentration: 38%
Beside the measured number, compound 3's estimate is 18 percentage points below it; measured number outside the range, above it.
By their numbers in this assay, from the lowest: compounds 2 and 1 (each within the scatter of the next); then compound 3.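

Putting chloro in place of methyl at this position, para to a large group, gives a number 21 percentage points higher from compound 2 to compound 3 (beyond the scatter) in this assay, so the group on this ring can move the result beyond the scatter. With the chloro kept, methyl in place of fluoro on an aromatic carbon at the other end of the molecule gives a number 18 percentage points higher from compound 1 to compound 3 (beyond the scatter), so compound 3 stands apart from each of the two earlier compounds through a single exchange. Among these compounds, compound 1 and compound 2, which differ in both places, gave no hint of either step. Their numbers could not be ranked. Nothing shown here explains why either exchange raises the number.

The compounds shown do not tell whether chloro would give the same step with fluoro in the second place, so it remains open whether the two exchanges act independently or only together. They also leave open how bromo, methoxy or an amine at the position para to a large group would compare with chloro, and whether any such group would go further.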